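A few compounds are considered here, and "the series" means these few. Any claim that something is new, unique, unknown or untested is made for them only; others in the source may bear on it.

The measured compounds are three. Compound 1, `C=C1[C@H](C)CCC[C@]1(C)CC/C(C)=C/CC1=C(O)C(=O)C=C(N[C@@H](C(=O)O)[C@H](C)O)C1=O`, gives in an ADME assay on KB cells (Homo sapiens) for cytotoxicity, with a stated time of 48 h (on this read-out lower numbers stand for stronger inhibition and higher numbers for weaker inhibition), only the limit > 10 ug/mL. Compound 2, `C=C1[C@H](C)CCC[C@]1(C)CC/C(C)=C/CC1=C(O)C(=O)C=C(N[C@@H](CO)C(=O)O)C1=O`, also gives only the limit > 10 ug/mL in this assay. Compound 3, `C=C1[C@H](C)CCC[C@]1(C)CC/C(C)=C/CC1=C(O)C(=O)C=C(N[C@@H](C(=O)O)C(C)C)C1=O`, gives 6.2 ug/mL in this assay.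

Compound 1 therefore stands at a limit rather than at a number, (the limit of > 10 ug/mL in this assay, at which 2 of the 3 values shown sit). Compound 4, `C=C1[C@H](C)CCC[C@]1(C)CC/C(C)=C/CC1=C(O)C(=O)C=C(OC)C1=O`, differs from it by methoxy in place of (1-carboxy-2-hydroxypropyl)amino on a double-bonded ring carbon. The measured steps all keep a substituted amine on that ring carbon and vary only its side chain: a step that the two limits leave unreadable from compound 1 to compound 2, and an at least 1.6-fold lower number from compound 1 to compound 3 (0.20 log units; that floor lies within the scatter), whose floor lies within the scatter. None exchanges the (1-carboxy-2-hydroxypropyl)amino group for a methoxy group, so they bear only weakly on compound 4. The step of an at least 2.0-fold lower number from compound 1 to compound 4 (0.30 log units; that floor lies within the scatter) is accordingly an estimate resting on little. Compound 4 is expected to give about 5 ug/mL in this assay, with a range from 1 ug/mL to 20 ug/mL.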

Compound 4, half-maximal inhibitory concentration: > 10 ug/mL
Compound 4 ended at the assay's limit; the forecaster's own chance of this, stated with the estimate: 30%; at least 2.0-fold (0.30 log units) between middle value and limit.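

In this assay compound 4 gives a limit and not a number, as do two of the amine-bearing compounds: the limit of > 10 ug/mL in this assay, at which 3 of the 4 values shown sit. Methoxy in place of (1-carboxy-2-methylpropyl)amino gives an at least 1.6-fold higher number from compound 3 to compound 4 (0.20 log units; that floor lies within the scatter) on this double-bonded ring carbon, so even the one measured number does not establish a firm loss on leaving the amine. The steps to compound 4 from compound 1 and compound 2 cannot be read.

From the compounds shown here alone, it stays open how an unsubstituted amine or a longer alkoxy chain on this ring carbon would read out in this assay. The true size of the methoxy change also remains unresolved.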